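The source may report more compounds than this note shows. Statements on the series, on what has been measured and on what is new or still open speak of the compounds shown alone.

Series notes, cytotoxicity on a pancreatic line.

Compound 1 `COc1ccc2c(c1)c(/C=N\NC(=O)c1cn(C)c3ccccc13)cn2Cc1ccc(Cl)cc1` and compound 2 `COc1ccc2c(c1)c(/C=N\NC(=O)c1c[nH]c3ccccc13)cn2Cc1ccc(Cl)cc1` share one core and differ only at the indole nitrogen. In a functional assay on MIA PaCa-2 cells (Homo sapiens) for cytotoxicity (on this read-out higher numbers stand for weaker inhibition and lower numbers for stronger inhibition), compound 1 gives 56400 nM, while compound 2 gives 26700 nM. The change between them is methyl in place of hydrogen on an aromatic nitrogen, and it made a 2.1-fold higher number from compound 2 to compound 1 (0.32 log units; beyond the scatter).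

Compound 3 `O=C(N/N=C\c1cn(Cc2ccc(Cl)cc2)c2cc(F)ccc12)c1c[nH]c2ccccc12` carries a different core; in this assay compound 3 gives 18000 nM. The difference between the core of compound 3 and the core of compound 2 is not broken down here, and the two values of compound 3 and compound 2 lie within the usual scatter of each other, so no order between them is claimed. Against compound 1 the gap is larger and beyond the scatter.

Compound 4 `Cn1cc(C(=O)N/N=C\c2cn(Cc3ccc(Cl)cc3)c3cc(F)ccc23)c2ccccc21` is not yet measured. It differs from compound 3 by methyl in place of hydrogen on an aromatic nitrogen, the same change that separates compound 2 from compound 1, on the same place in the same ring system. Within the data shown here, the only precedent for this change is the single pair of compound 2 and compound 1, so the expectation rests on one step alone, with no second pair to show whether it carries across cores.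

On that basis the step from compound 3 to compound 4 is expected to be about a 2.1-fold higher number from compound 3 to compound 4 (0.32 log units; beyond the scatter) in this assay, a modest rise of the number because of a 2.1-fold higher number from compound 2 to compound 1 (0.32 log units; beyond the scatter). Compound 4 is therefore estimated at 38000 nM in this assay, with a plausible range from 18000 nM to 80000 nM.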

Compound 4, half-maximal inhibitory concentration: 50400 nM
For compound 4 the middle estimate is 1.3-fold (0.12 log units) below the measured one; measured number inside the range.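

In this assay, the change from 1H-indol-3-yl to 1-methyl-1H-indol-3-yl gave a 2.8-fold higher number from compound 3 to compound 4 (0.45 log units; beyond the scatter), so on the core of compound 3 methyl in place of hydrogen on the aromatic nitrogen again goes with weaker inhibition. Set beside the earlier step, the new one runs in the same direction and cannot be told apart from it in size: the same change on two cores in this assay, a 2.1-fold higher number (0.32 log units; beyond the scatter) from compound 2 to compound 1 and a 2.8-fold higher number (0.45 log units; beyond the scatter) from compound 3 to compound 4, 1.3-fold (0.12 log units) apart, within the scatter of two such steps. Among these compounds, this shows that the change carried over between these two cores in this assay, but with only two pairs it does not show that it would hold on a third core, and it gives no account of why the number rises.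

The compounds shown leave open whether a larger group on the same aromatic nitrogen, such as ethyl, a longer chain ending in an amine or one ending in a carboxylic acid, would extend the rise or reverse it. Also open, from the compounds shown here alone, is whether the step holds on a core with a quite different starting value, as the two parents, compound 2 (26700 nM) and compound 3 (18000 nM), lie within the usual scatter of each other.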